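Changing the aryl group on a dihydropyridine core

A few compounds are considered here, and "the series" means these few. Any claim that something is new, unique, unknown or untested is made for them only; others in the source may bear on it.

Measured so far:
compound 1, `COC(=O)C1=C(C)N=C(C)/C(=C(\O)OC)C1c1cccc(Cl)c1Cl`, 19.1 nM
compound 2, `COC(=O)C1=C(C)N=C(C)/C(=C(\O)OC)C1c1cccc(N(C)C)c1`, 891 nM
compound 3, `COC(=O)C1=C(C)N=C(C)/C(=C(\O)OC)C1c1ccc(Br)cc1`, 540 nM

The three compounds share one core and differ only in the aryl group on a saturated ring carbon. In a functional assay (muscle tissue) with Cavia porcellus as the target (on this read-out higher numbers stand for an effect only at larger amounts of compound and lower numbers for an effect already at smaller amounts), compound 3 gives the second highest of the three numbers. Its nearest neighbour is compound 2, and the gap between them lies within the scatter; its furthest neighbour is compound 1, and the step of a 28-fold higher number from compound 1 to compound 3 (1.45 log units; beyond the scatter) is large and beyond the scatter.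

Compound 4, `COC(=O)C1=C(C)N=C(C)/C(=C(\O)OC)C1c1cccc(O)c1`, has not yet been measured. It differs from compound 3 in one place: 3-hydroxyphenyl in place of 4-bromophenyl on a saturated ring carbon. For the measured compounds named here, only one measured step touches this position, a 28-fold higher number from compound 1 to compound 3 (1.45 log units; beyond the scatter), and it shows that the aryl group can move the number a long way. Compound 2 and compound 3 show that two quite different aryl groups can also give numbers within the scatter of each other. Going by the values given here, no measured step involves a 3-hydroxyphenyl group, so the direction is uncertain. For compound 4 the expected step is a 2.2-fold higher number from compound 3 to compound 4 (0.35 log units; beyond the scatter), and the estimate in this assay is 1200 nM, with a range from 300 nM to 5000 nM.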

Compound 4, half-maximal effective concentration: 1000 nM
For compound 4 the middle estimate is 1.2-fold (0.08 log units) above the measured one, and the stated range covers the measured number.
By their numbers in this assay, from the lowest: compound 1; then compounds 3, 2 and 4 (each within the scatter of the next).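

In this assay, putting 3-hydroxyphenyl, which has a hydrogen-bond donor, in place of 4-bromophenyl, which has none, gives a 1.9-fold higher number from compound 3 to compound 4 (0.27 log units; within the scatter) and so does not separate the two groups. Hydroxy in place of dimethylamino on an aromatic carbon gives a 1.1-fold higher number from compound 2 to compound 4 (0.05 log units; within the scatter) and likewise separates nothing, so three quite different aryl groups now sit together. Only the 2,3-dichlorophenyl group stands apart, with a 52-fold higher number from compound 1 to compound 4 (1.72 log units; beyond the scatter) as a large step, and nothing shown here says why.

The compounds shown leave open whether the low number of compound 1 needs both chlorine atoms or would survive on a phenyl ring carrying a single chlorine. They also leave open how a plain unsubstituted phenyl, or a phenyl ring bearing a carboxylic acid or a primary amine, would compare.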